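Succinimide amides in the maximal electroshock model: notes

This account rests on a few compounds, and the source may have more. Where it says the series, first, only, none or still open, it means among the compounds named here.

Measured compounds:
compound 1 `COCC(C(=O)N1CCN(c2cccc(C(F)(F)F)c2)CC1)N1C(=O)CCC1=O`, 100%
compound 2 `CCC(C(=O)N1CCN(c2ccccc2Cl)CC1)N1C(=O)CCC1=O`, 50%
compound 3 `CCC(C(=O)N1CCOCC1)N1C(=O)CCC1=O`, 0%

In a functional assay on the whole organism (strain Swiss) with Mus musculus as the target, in the maximal electroshock model, with a stated time of 1 h, at a dose of 300 mg/kg by the intraperitoneal route (on this read-out higher numbers stand for a stronger effect at the one dose given and lower numbers for a weaker effect), compound 1 gives 100%, the highest of the three numbers; compound 2 stands lower by a margin beyond the scatter, and compound 3 lower still, also beyond the scatter. Among the measured compounds shown here, no pair among the measured compounds differs in only one place, so no single step is known.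

Compound 4 `CC(C(=O)N1CCN(c2cccc(C(F)(F)F)c2)CC1)N1C(=O)CCC1=O` differs from compound 1 in one place: hydrogen in place of methoxy on a saturated chain carbon, two bonds along the chain from an amide-type nitrogen in a ring and a carbonyl carbon. Compounds 2 and 3 carry a methyl rather than a methoxymethyl at this position and give weaker read-outs, but they also differ elsewhere, so no clean reading of the methoxy is available.

A step of moderate size downward is expected, a number 30 percentage points lower from compound 1 to compound 4 (beyond the scatter). Compound 4 is estimated at 70%, between 30% and 100%.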

Compound 4, a percentage reported as activity, at one dose (the size of the read-out at that dose, not a potency): 100%
Estimate against measurement, compound 4: 30 percentage points below; low and high end bracket the measured number.
By their numbers in this assay, from the lowest: compound 3; then compound 2; then compounds 1 and 4 (each within the scatter of the next).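

In this assay, hydrogen in place of methoxy on this saturated chain carbon gives no change at the digits printed from compound 1 to compound 4 (within the scatter). The methoxy is therefore not required for the read-out at this one dose, and with the core of compound 1 a methyl at this position still gives compound 4 100%. No measurement at hand accounts for this result.

As far as these compounds go, whether an amine, a carboxylic acid or a longer chain at this position would keep the read-out remains open. From the compounds shown here alone, a single-dose read-out is not a potency, so any difference in potency between compound 1 and compound 4 also remains open.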